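The source may hold more compounds than are shown below. What is called first, only, known or untested is meant among the compounds shown, and "the series" means these compounds.

Measured so far in an assay on PC-12 cells for displacement of a labelled ligand from vesicular acetylcholine transporter (Homo sapiens); a higher number here means a weaker inhibitor, a lower number a stronger inhibitor:
- compound 1, `OC1CNCCC1N1CCN(c2ccccc2)CC1`, gives 100 nM
- compound 2, `OC1CN(Cc2ccccc2)CCC1N1CCN(c2ccccc2)CC1`, gives 57 nM
- compound 3, `C=CCN1CCC(N2CCN(c3ccccc3)CC2)C(O)C1`, gives only a limit of the assay, > 100 nM

All three share one core and differ only in what sits on the amine nitrogen in a ring. From the compounds shown here alone, compound 3 stands at the edge of what this assay reports: its value is a limit, not a number, so its exact place remains open, a situation described by the limit of > 100 nM in this assay, at which 1 of the 3 values shown sits. Compound 4, `OC1CN(C/C=C/I)CCC1N1CCN(c2ccccc2)CC1`, is the next step: 2-iodoethenyl in place of vinyl on a saturated chain carbon bound to an amine nitrogen in a ring.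

Going by the values given here, three measured steps bear on this. The step of a 1.8-fold lower number from compound 1 to compound 2 (0.24 log units; within the scatter) and the step of an at least 1.7-fold higher number from compound 2 to compound 3 (0.24 log units; that floor lies within the scatter) are both small, and the step of a number no lower from compound 1 to compound 3 (the limit leaves the size open) cannot be sized because of the limit. The change from compound 3 to compound 4 is smaller than any of these, so no step beyond the scatter is expected, and the estimated step that the limit leaves unreadable from compound 3 to compound 4 reflects that. Compound 4 is therefore expected to give about 150 nM, in a range from 50 nM to 500 nM, with a fair chance that only a limit is reported again.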

Compound 4, half-maximal inhibitory concentration: > 100 nM
Compound 4: a limit, no number; the forecaster's own chance of this, stated with the estimate: 45%; the middle value does not contradict the limit.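

With 2-iodoethenyl in place of vinyl on a saturated chain carbon bound to an amine nitrogen in a ring, this assay shows a step that the two limits leave unreadable from compound 3 to compound 4, so a second group at this position now ends at the edge of what the assay reports: the limit of > 100 nM in this assay, at which 2 of the 4 values shown sit.

Going by these compounds alone, of the new steps, only the one against the benzyl compound can be read, and it is an at least 1.7-fold higher number from compound 2 to compound 4 (0.24 log units; that floor lies within the scatter); this gives only a floor, so the real gap may be small or large. The step of a number no lower from compound 1 to compound 4 (the limit leaves the size open) cannot be read, and neither can the step between the two limits.

From the compounds shown here alone, how far compound 3 and compound 4 each lie past the limit stays open, and with it whether adding iodine shifts the value at all. Also open, going by these compounds, is what a saturated propyl chain or a carboxylic acid on this nitrogen would give.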